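A Methylated Hydantoin Replaces the Triazole Carboxamide

A few compounds are considered here, and "the series" means these few. Any claim that something is new, unique, unknown or untested is made for them only; others in the source may bear on it.

Compound 2 `CCO/C(O)=C1\C(COCCn2nncc2C(N)=O)=NC(C)=C(C(=O)OC)C1c1ccccc1Cl` gives 100 nM in a functional assay (aorta) with Rattus norvegicus as the target (a higher number here means a weaker inhibitor, a lower number a stronger inhibitor), the highest of the three numbers measured. Its nearest neighbour is compound 3 `CCO/C(O)=C1\C(COCCN2C(=O)CNC2=O)=NC(C)=C(C(=O)OC)C1c1ccccc1Cl`, which gives 31.6 nM in this assay; the step of a 3.2-fold lower number from compound 2 to compound 3 (0.50 log units; beyond the scatter) is modest but beyond the scatter. Furthest away is compound 1 `CCO/C(O)=C1\C(COCCn2cc(C(N)=O)nn2)=NC(C)=C(C(=O)OC)C1c1cccc(Cl)c1Cl`, which gives 3.16 nM in this assay; compound 1 differs from compound 2 in more than one place, so only the two values are set side by side and no single step is read from them.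

Compound 4 `CCO/C(O)=C1\C(COCCN2CC(=O)N(C)C2=O)=NC(C)=C(C(=O)OC)C1c1ccccc1Cl` differs from compound 2 in one place: 3-methyl-2,4-dioxoimidazolidin-1-yl in place of 5-carbamoyl-1H-1,2,3-triazol-1-yl on a saturated chain carbon, two bonds along the chain from an oxygen on a saturated carbon. Going by the values given here, the one measured step that bears on this change is a 3.2-fold lower number from compound 2 to compound 3 (0.50 log units; beyond the scatter), in which the same ring entered without the methyl. Among the compounds with values here, the change to compound 4 is therefore expected to give a step of similar size in the same direction, a 2.9-fold lower number from compound 2 to compound 4 (0.46 log units; beyond the scatter); nothing among the measured compounds speaks to the methyl itself. The estimate for compound 4 in this assay is 35 nM, with a range from 10 nM to 120 nM.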

Compound 4, half-maximal inhibitory concentration: 25.1 nM
Estimate against measurement, compound 4: 1.4-fold (0.14 log units) above, within the range that was stated.
By their numbers in this assay, from the lowest: compound 1; then compounds 4 and 3 (each within the scatter of the next); then compound 2.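

In this assay, the ring keeps its advantage over the triazole when it carries the methyl, with a 4.0-fold lower number from compound 2 to compound 4 (0.60 log units; beyond the scatter), so the change at this saturated chain carbon does not depend on the unmethylated ring of compound 3. The earlier compounds shown here could not speak to the methyl itself, and a 1.3-fold lower number from compound 3 to compound 4 (0.10 log units; within the scatter) now shows no difference that can be told from the scatter, while the step from compound 2 holds for a group with 0 hydrogen-bond donors. No measurement at hand accounts for either step.

The compounds shown leave open whether an ethyl or benzyl group in place of the methyl, or a longer chain before the ring, would alter the number. As far as these compounds go, it also remains open whether 3-methyl-2,4-dioxoimidazolidin-1-yl would carry over to the core of compound 1, which gives 3.16 nM with its triazole carboxamide.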